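Replacing the amide-side aryl group in a dopamine receptor agonist series

This account rests on a few compounds, and the source may have more. Where it says the series, first, only, none or still open, it means among the compounds named here.

The compounds share a core built from a piperazine carrying a chloropyridine on one side and an acetamide on the other. Compound 1 `Cc1cccc(NC(=O)CN2CCN(c3ccc(Cl)cn3)CC2)c1` was tested in an assay on cells for agonist activity at D(4) dopamine receptor (Homo sapiens), read by luminescence and beta-arrestin recruitment, with a stated time of 90 min (a higher number here means a larger maximal response, a lower number a smaller maximal response), and came out as "not active" (no number reported), so no single number describes where compound 1 stands; the measurement only says that no response worth reporting was seen. A close relative without the chlorine, compound 2 `Cc1cccc(NC(=O)CN2CCN(c3ccccn3)CC2)c1`, gives 30.7% in this assay, which shows that a modest maximal response is reachable in this family.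

Compound 3 `O=C(CN1CCN(c2ccc(Cl)cn2)CC1)Nc1cncnc1` differs from compound 1 in one place: pyrimidin-5-yl in place of 3-methylphenyl on an amide-type nitrogen. Among the measured compounds shown here, no measured pair shows this exact change, so its effect is unknown. Given that compound 1 is "not active" (no number reported), the expectation for compound 3 is a small response, with a real chance that the assay again reports no number. The maximal response of compound 3 in this assay is estimated at 15%, within a range from 0% to 40%.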

Compound 3, largest response reached (Emax), in percent of the reference or control that the assay uses: "not active" (no number reported)
Compound 3 has no reported number here; no gap can be computed for the estimate.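

Compound 1 and compound 3 both come out without a number in this assay, so no step can be read for pyrimidin-5-yl in place of 3-methylphenyl. On these data alone, it remains open whether this swap would change the response in a compound that gives a measurable one, such as compound 2. No supporting measurement bears on this result.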